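Swapping acetyl for dimethylamino on a pyrazole-based scaffold

This account rests on a few compounds, and the source may have more. Where it says the series, first, only, none or still open, it means among the compounds named here.

Compound 1, `COc1cc(C)cc(-c2c(-c3ccnc(-c4ccc(C(C)=O)cc4)c3)cnn2CC#N)c1`, was tested in a functional assay on KM12 cells (Homo sapiens) for inhibition, read by sulforhodamine B assay, with a stated time of 48 h (a lower number here means that less compound is tolerated, a higher number that more compound is tolerated), and for compound 1 the result is only a limit, > 100000 nM, meaning no number could be fixed for it. This is the situation described by the limit of > 100000 nM in this assay, at which 1 of the 2 values shown sits. A related compound, compound 2, `COc1cc(C)cc(-c2nn(CC#N)cc2-c2ccnc(-c3ccc(N(C)C)cc3)c2)c1`, carries the same dimethylamino-bearing arm on a differently joined core; in this assay compound 2 gives 25500 nM, a number rather than a limit. Compound 3, `COc1cc(C)cc(-c2c(-c3ccnc(-c4ccc(N(C)C)cc4)c3)cnn2CC#N)c1`, keeps the core of compound 1 and differs from it in a single place: dimethylamino in place of acetyl on an aromatic carbon. Going by the values given here, no measured pair here shows this exact swap, so its effect can only be expected, not read off. Because compound 2 gives 25500 nM with the same dimethylamino group in place, compound 3 is expected to reach a measurable value, an expected step of an at least 2.8-fold lower number from compound 1 to compound 3 (0.45 log units; beyond the scatter) in the direction of less compound tolerated. The estimate for compound 3 in this assay is 35000 nM, with a range from 9000 nM to 130000 nM, and a real chance remains that only a limit is reported again.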

Compound 3, concentration lethal to 50% of the cells: > 100000 nM
Compound 3: no number, only a limit; the forecaster's own chance of this, stated with the estimate: 30%; at least 2.8-fold (0.45 log units) between middle value and limit.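

Compound 1 and compound 3 both give a limit rather than a number in this assay, and no step between them can be read because of this: the limit of > 100000 nM in this assay, at which 2 of the 3 values shown sit.

The compounds shown leave open how much, if at all, dimethylamino in place of acetyl changes the lethal concentration on the core of compound 1.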